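A methyl on the ring carbon of compound 1

A few compounds are considered here, and "the series" means these few. Any claim that something is new, unique, unknown or untested is made for them only; others in the source may bear on it.

Compound 1 `Nc1oncc1-c1ccccc1`: 0%
Compound 2 `CNc1oncc1-c1ccccc1`: 0.1%

In an ADME assay on blood (Rattus norvegicus) for metabolic stability, read by LC-MS, with a stated time of 2 h, tested at 0.5 mM (on this read-out higher numbers stand for a more stable compound and lower numbers for a less stable compound), compound 1 gives 0%, the bottom of the scale, and compound 2 lies within the scatter of it. Compound 3 `Cc1noc(N)c1-c1ccccc1` has not yet been measured. Its structure differs from that of compound 1 in one place: methyl in place of hydrogen on an aromatic carbon. This is a methyl in place of hydrogen on an aromatic carbon, next to the ring nitrogen.

Among the measured compounds shown here, only one measured step comes close to this change: a number 0.1 percentage points higher from compound 1 to compound 2 (within the scatter). That methyl stands in place of hydrogen on a nitrogen, however, not on an aromatic carbon, so it is a weak guide. Compound 1 and compound 2 both keep the hydrogen that compound 3 replaces, which means the data contain no test of this change. Starting from the bottom of the scale, any real step can only go upward. A large upward step is expected here, but with much uncertainty. The expected step is a number 65 percentage points higher from compound 1 to compound 3 (beyond the scatter). For compound 3 the estimated value is 65%, with an expected range of 10% to 100%.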

Compound 3, percent of the compound remaining: 50%
The estimate for compound 3 lay 15 percentage points above the measured number; measured number inside the range.
By their numbers in this assay, from the lowest: compounds 1 and 2 (each within the scatter of the next); then compound 3.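

In this assay a methyl in place of hydrogen on an aromatic carbon, next to the ring nitrogen, lifts the compound clear of the bottom of the scale (a number 50 percentage points higher from compound 1 to compound 3 (beyond the scatter)). Among the compounds shown here, this shows that this ring carbon responds strongly to a change of a single carbon atom, which the earlier compounds could not show. For the compounds shown here, the only earlier step put a methyl in place of hydrogen on a nitrogen instead, and it stayed within the usual variation between repeats (a number 0.1 percentage points higher from compound 1 to compound 2 (within the scatter)), so the same small group has very different outcomes at these two places. No measurement here explains why the methyl on the ring carbon has this outcome.

From the compounds shown here alone, whether an ethyl group, a longer chain, trifluoromethyl, an amine or a carboxylic acid on this same carbon would hold, raise or lower the percentage remaining stays open. Going by these compounds, it is also open whether the methyl on the ring carbon would make the same difference with a second methyl on the nitrogen, as that nitrogen carries in compound 2.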